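Adding a hydroxy group to compound 2

The source may hold more compounds than are shown below. What is called first, only, known or untested is meant among the compounds shown, and "the series" means these compounds.

Results so far in an ADME assay on DU-145 cells (Homo sapiens) for cytotoxicity, read by MTT assay, with a stated time of 72 h (on this read-out lower numbers stand for stronger inhibition and higher numbers for weaker inhibition), for three compounds:
- compound 1 (`COc1ccc(C2=C(c3cc(OC)c(OC)c(OC)c3)C(=O)C(OC(C)=O)C2)cc1`) gives > 100 ug/mL
- compound 2 (`COc1ccc(C2=C(c3cc(OC)c(OC)c(OC)c3)C(=O)CC2O[SiH2]C(C)(C)C)cc1`) gives > 100 ug/mL
- compound 3 (`COc1ccc(C2=C(c3cc(OC)c(OC)c(OC)c3)C(=O)CC2OC(C)=O)cc1NC=O`) gives > 100 ug/mL

None of these results is a true number, and the summary is simple: the limit of > 100 ug/mL in this assay, at which 3 of the 3 values shown sit, is the whole picture so far. Compound 2 gives > 100 ug/mL and this is a limit. It therefore stands level with the other two compounds, with nothing to separate them.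

The next compound is compound 4 (`COc1ccc(C2=C(c3cc(OC)c(OC)c(OC)c3)C(=O)CC2O[SiH2]C(C)(C)C)cc1O`), which carries one change from compound 2 (hydroxy in place of hydrogen on an aromatic carbon) and so has hydroxy in place of hydrogen on an aromatic carbon. In other words, 4-methoxyphenyl becomes 3-hydroxy-4-methoxyphenyl.

For the measured compounds named here, no pair of measured compounds shows this change on its own, so the expectation is a cautious one. With all three results at the limit, any measurable value could only lie on the side of stronger inhibition. The estimated step of an at least 2.5-fold lower number from compound 2 to compound 4 (0.39 log units; beyond the scatter) points that way, though the result may just as well stay at the limit. For compound 4 the expected value is 40 ug/mL with 3 ug/mL to 150 ug/mL as the estimated range.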

Compound 4, half-maximal inhibitory concentration: 75 ug/mL
Beside the measured number, compound 4's estimate is 1.9-fold (0.27 log units) below it, and the stated range covers the measured number.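

In this assay, for the compounds shown here, compound 4 gives 75 ug/mL, the first true number in this set, so this aromatic carbon, ortho to a methoxy group, is a place where one small change can bring a compound within the measurable range. Going by these compounds, the step is an at least 1.3-fold lower number from compound 2 to compound 4 (0.12 log units; that floor lies within the scatter); it is only a floor, so the real size of the change stays unknown and these two results alone do not establish a difference beyond normal scatter. The other results remain at the ceiling, which is why compound 4 has no measured partner for a direct comparison: the limit of > 100 ug/mL in this assay, at which 3 of the 4 values shown sit.

Still open, on these data alone, is whether this result is specific to the hydroxy group, which an amino group, a fluorine atom or an ethoxy group on the same carbon could test. It is also unclear whether the hydroxy group would give a measurable value with the silyl ether of compound 4 replaced by a free alcohol or an amine.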